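Replacing bromo with acetamido in a small sulfonamide series

The source may hold more compounds than are shown below. What is called first, only, known or untested is meant among the compounds shown, and "the series" means these compounds.

In a functional assay on QGY-7703 cells (Homo sapiens) for cytotoxicity, read by MTT assay, with a stated time of 24 h (a higher number here means a weaker inhibitor, a lower number a stronger inhibitor), compound 1 `Cc1ccc(S(=O)(=O)N2C/C(=C\c3ccncc3)C(=O)/C(=C/c3ccccc3C(F)(F)F)C2)cc1` gives 5090 nM, compound 2 `O=C1/C(=C/c2ccncc2)CN(S(=O)(=O)c2ccc(Cl)cc2)C/C1=C\c1ccccc1C(F)(F)F` gives 12700 nM and compound 3 `O=C1/C(=C/c2ccncc2)CN(S(=O)(=O)c2ccc(Br)cc2)C/C1=C\c1ccccc1C(F)(F)F` gives 7060 nM. Compound 3 stands within the scatter of both other compounds, with a 1.4-fold higher number from compound 1 to compound 3 (0.14 log units; within the scatter) and a 1.8-fold lower number from compound 2 to compound 3 (0.25 log units; within the scatter). Only the remaining pair differs beyond the scatter, with a 2.5-fold higher number from compound 1 to compound 2 (0.40 log units; beyond the scatter), and even that step is modest.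

Compound 4 `CC(=O)Nc1ccc(S(=O)(=O)N2C/C(=C\c3ccncc3)C(=O)/C(=C/c3ccccc3C(F)(F)F)C2)cc1` has acetamido in place of bromo on an aromatic carbon, para to a large group: acetamido in place of bromo on an aromatic carbon. The measured steps exchange only methyl, chloro and bromo, so they bear on this change only indirectly. None of them tests acetamido, and together they show no direction that could be carried over. No step beyond the scatter is therefore expected, though the uncertainty is wide. The expected change is a 1.1-fold higher number from compound 3 to compound 4 (0.03 log units; within the scatter). For compound 4 the estimated value is 7500 nM, with an expected range of 3000 nM to 19000 nM.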

Compound 4, half-maximal inhibitory concentration: 5560 nM
Compound 4: middle estimate off by 1.3-fold (0.13 log units), on the high side; low and high end bracket the measured number.
By their numbers in this assay, from the lowest: compounds 1, 4, 3 and 2 (each within the scatter of the next, the first and the last beyond it).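

In this assay, 4-acetamidophenyl in place of 4-bromophenyl gives a 1.3-fold lower number from compound 3 to compound 4 (0.10 log units; within the scatter) and so stays within the scatter, even though acetamido brings a hydrogen-bond donor and a hydrogen-bond acceptor that bromo does not have. Acetamido also cannot be told apart from methyl, with a 1.1-fold higher number from compound 1 to compound 4 (0.04 log units; within the scatter) as the step, and only the comparison with chloro passes the scatter, with a 2.3-fold lower number from compound 2 to compound 4 (0.36 log units; beyond the scatter) as a modest step. Nothing shown here accounts for these numbers.

The compounds leave open whether an amine, a carboxylic acid or a longer acyl chain at this position would stay in the same range. All four also carry trifluoromethyl on the shared core, so they do not show whether these steps would hold with a nitrile there instead.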